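Trimethoxy Chalcone Pyrazoles Against MDA-MB-435 Cells

The compounds below may be only part of what the source reports. "The series", "measured", "known", "first", "only" and "open" are said of these compounds alone.

Compound 1 `COc1ccc(-c2cc(/C=C/C(=O)c3ccc(N)cc3)[nH]n2)cc1`: -16%
Compound 2 `COc1ccc(-c2cc(/C=C/C(=O)c3ccc(N)cc3)[nH]n2)cc1OC`: -15%
Compound 3 `COc1cc(C(=O)/C=C/c2cc(-c3cc(OC)c(OC)c(OC)c3)n[nH]2)cc(OC)c1OC`: -90%

In a functional assay on MDA-MB-435 cells (Homo sapiens) for cytotoxicity, read by sulforhodamine B assay, with a stated time of 48 h, tested at 10 uM (a higher number here means a weaker effect of the compound at the concentration tested, a lower number a stronger effect), compound 1 gives -16% and compound 2 gives -15%; the step of a number 1 percentage points lower from compound 2 to compound 1 (within the scatter) is hydrogen in place of methoxy on an aromatic carbon. Compound 3 stands lowest in this assay with -90%; how its core differs from the core of compound 2 is not broken down here.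

Compound 4 `COc1ccc(-c2cc(/C=C/C(=O)c3cc(OC)c(OC)c(OC)c3)[nH]n2)cc1OC` has not yet been measured. It differs from compound 3 by hydrogen in place of methoxy on an aromatic carbon, the same kind of change as that from compound 2 to compound 1, but here the place is also meta to a methoxy group. The expected step of a number 8 percentage points higher from compound 3 to compound 4 (within the scatter) rests on the small step of a number 1 percentage points lower from compound 2 to compound 1 (within the scatter) seen for compound 2 to compound 1. Compound 4 is estimated at -82%, between -96% and -50%.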

Compound 4, a percentage reported as activity, at one concentration (the size of the read-out at that concentration, not a potency): -55%
The estimate for compound 4 lay 27 percentage points below the measured number; the measured number falls inside the stated range.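

The change does not carry a fixed effect from one core to the other in this assay: the same change on two cores in this assay, a number 1 percentage points lower (within the scatter) from compound 2 to compound 1 and a number 35 percentage points higher (beyond the scatter) from compound 3 to compound 4, 36 percentage points apart, beyond the scatter of two such steps.

On the core of compound 3, where the place is ortho to a methoxy group, hydrogen in place of methoxy gives a large step, a number 35 percentage points higher from compound 3 to compound 4 (beyond the scatter), so a flat result on one core did not predict the result on the other. Two pairs do not show which feature of the cores sets this gap, nor how the change would behave on any further core.

The compounds shown leave open how a hydroxyl group, an ethoxy group or a chlorine atom would read at this place. They also leave open whether the gap would persist in another assay.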